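The source may report more compounds than this note shows. Statements on the series, on what has been measured and on what is new or still open speak of the compounds shown alone.

Measured compounds in an assay on microsomes from liver for inhibition of sterol O-acyltransferase 1 (Rattus norvegicus); a lower number here means a stronger inhibitor, a higher number a weaker inhibitor:

Compound 1, `CCCCCCCCC(c1ccccc1)S(=O)(=O)NC(=O)Nc1c(C(C)C)cccc1C(C)C`, 9200 nM.
Compound 2, `CCCCCCCCCCS(=O)(=O)NC(=O)Nc1c(C(C)C)cccc1C(C)C`, 13600 nM.
Compound 3, `CCCCCCCCCCCCS(=O)(=O)NC(=O)Nc1c(C(C)C)cccc1C(C)C`, 3300 nM.

Compound 3 holds the lowest number of the three. Among the compounds with values here, the only single-site step measured, a 4.1-fold lower number from compound 2 to compound 3 (0.62 log units; beyond the scatter), concerns ethyl in place of hydrogen on a saturated chain carbon, distant along the chain from the sulfonyl sulfur. Compound 4, `CCCCCCCCCCCCS(=O)(=O)N(C)C(=O)Nc1c(C(C)C)cccc1C(C)C`, differs from compound 3 by methyl in place of hydrogen on an amide-type nitrogen. Within the data shown here, no measured step touches this nitrogen, so nothing here tells the direction; the chain step gives no guide. A change at this position is expected to weaken inhibition more often than not, but with wide uncertainty. Compound 4 is therefore estimated at 8000 nM, range 2000 nM to 40000 nM, a step of a 2.4-fold higher number from compound 3 to compound 4 (0.38 log units; beyond the scatter) expected.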

Compound 4, half-maximal inhibitory concentration: 675 nM
Compound 4: middle estimate off by 12-fold (1.07 log units), on the high side; measured number outside the range, below it.
By their numbers in this assay, from the lowest: compound 4; then compound 3; then compounds 1 and 2 (each within the scatter of the next).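

Methyl in place of hydrogen on the amide-type nitrogen gives a 4.9-fold lower number from compound 3 to compound 4 (0.69 log units; beyond the scatter) in this assay. This nitrogen therefore accepts substitution in compound 4, and the hydrogen on it is not required for inhibition. No measured evidence bears on the reason for this step.

Open, on these data alone, is whether ethyl or benzyl on this nitrogen would give a lower or a higher number than methyl. Also open, as far as these compounds go, is whether methyl at this nitrogen gives a comparable step on the chains of compound 1 and compound 2.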